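Amide nitrogen substituent in thiophenylmethyl aryloxyacetamides

The compounds below may be only part of what the source reports. "The series", "measured", "known", "first", "only" and "open" are said of these compounds alone.

Compound 2 `Cc1ccc(OCC(=O)N(Cc2cccs2)C(C)(C)C)cc1` gives 11000 nM in an assay on HEK293 cells for agonist activity at transient receptor potential cation channel subfamily M member 8 (Homo sapiens), read by fluorescence and calcium flux, with a stated time of 15 min (a lower number here means that less compound is needed, a higher number that more compound is needed for the effect), the higher of the two numbers recorded there. Compound 1 `CCN(Cc1cccs1)C(=O)c1cc2cc(C)ccc2s1`, the nearest neighbour by value, gives 1600 nM in this assay, a gap beyond the scatter. Compound 3 `CCN(Cc1ccncc1)C(=O)COc1ccc(C)cc1` is reported as "not active" (no number reported) in this assay, with no number attached.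

Compound 4 `Cc1ccc(OCC(=O)N(Cc2cccs2)C2CC2)cc1` differs from compound 2 in one place: cyclopropyl in place of tert-butyl on an amide-type nitrogen. For the measured compounds named here, no measured pair shows this change, so the direction rests on expectation alone. A modest shift toward a lower number is expected, a 1.8-fold lower number from compound 2 to compound 4 (0.26 log units; within the scatter), but not clearly beyond the scatter. For compound 4 the estimate in this assay is 6000 nM, within a range from 2000 nM to 20000 nM.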

Compound 4, half-maximal effective concentration: 8 nM
For compound 4 the middle estimate is 750-fold (2.88 log units) above the measured one; the measured number lies below the stated range.
By their numbers in this assay, from the lowest: compound 4; then compound 1; then compound 2.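

In this assay, for the compounds shown here, the step of a 1400-fold lower number from compound 2 to compound 4 (3.14 log units; beyond the scatter) is large and beyond the scatter, the first reading at this position with everything else held constant. On an amide-type nitrogen, this one exchange of tert-butyl for cyclopropyl therefore decides most of the activity of this pair. Nothing available accounts for the size of the step. From the compounds shown here alone, whether it follows from gaining the three-membered ring or from losing tert-butyl stays open. Isopropyl or cyclobutyl on the same nitrogen would bear on that, and how far the result extends to other substituents is unknown.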